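Ring substituent step in the shared-core cytotoxicity series

This account rests on a few compounds, and the source may have more. Where it says the series, first, only, none or still open, it means among the compounds named here.

compound 1 `Cc1nc(C)c(C(=O)Oc2ccccc2/C=C/C(=O)O)nc1C`: 61.8%
compound 2 `COc1ccc(OC(=O)c2nc(C)c(C)nc2C)c(/C=C/C(=O)O)c1`: 45%

In a functional assay on EA.hy 926 cells (Homo sapiens) for cytotoxicity, read by MTT assay, with stated times of 24 h and 12 h, tested at 25 uM (on this read-out higher numbers stand for a stronger effect at the one concentration tested and lower numbers for a weaker effect), compound 1 gives 61.8% and compound 2 gives 45%. Compound 2 stands lowest of the two, with compound 1 the nearer and higher neighbour; the step of a number 16.8 percentage points lower from compound 1 to compound 2 (beyond the scatter) lies beyond the scatter.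

Compound 3 `Cc1nc(C)c(C(=O)Oc2ccc(Cl)cc2/C=C/C(=O)O)nc1C` is not yet measured. It differs from compound 2 as follows: chloro in place of methoxy on an aromatic carbon. Among the measured compounds shown here, the only measured step that bears on this position is a number 16.8 percentage points lower from compound 1 to compound 2 (beyond the scatter), a modest drop when methoxy entered in place of hydrogen on that aromatic carbon. For the measured compounds named here, no measured pair shows chloro at this place, so the size of the step to compound 3 is uncertain; the methoxy that lowered the number leaves, and a single heavy atom enters. Compound 3 is expected to come out somewhat higher than compound 2, roughly midway back toward compound 1, an expected step of a number 9 percentage points higher from compound 2 to compound 3 (within the scatter). The estimate for compound 3 is 54%, within 38% to 70%.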

Compound 3, a percentage reported as activity, at one concentration (the size of the read-out at that concentration, not a potency): 26%
For compound 3 the middle estimate is 28 percentage points above the measured one; the measured number lies below the stated range.
By their numbers in this assay, from the lowest: compound 3; then compound 2; then compound 1.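

At this place, para to a large group and meta to a 2-carboxyethenyl group, both substituents shown lower the number in this assay, so the loss is not confined to methoxy. Chloro goes further than methoxy, with a number 19 percentage points lower from compound 2 to compound 3 (beyond the scatter), and the change from hydrogen to chloro gives a number 35.8 percentage points lower from compound 1 to compound 3 (beyond the scatter), so the count of heavy atoms in the entering group does not set the order among these three compounds. No evidence is available on what lies behind this order.

From the compounds shown here alone, whether an amine, a carboxylic acid or a longer chain at this place would also lower the number remains open. Also open, going by these compounds, is whether chloro and methoxy keep this order elsewhere on the same aromatic ring.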